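The source may hold more compounds than are shown below. What is called first, only, known or untested is meant among the compounds shown, and "the series" means these compounds.

Measured compounds in an assay on HEK293 cells for agonist activity at transient receptor potential cation channel subfamily M member 8 (Homo sapiens), read by fluorescence and calcium flux, with a stated time of 15 min; on this read-out lower numbers stand for an effect already at smaller amounts and higher numbers for an effect only at larger amounts of compound:
- compound 1 `CCN(Cc1cccs1)C(=O)COc1ccc(C(=O)O)cc1`: "not active" (no number reported)
- compound 2 `CCN(Cc1cccs1)C(=O)COc1ccc(F)cc1`: 422 nM
- compound 3 `CCN(Cc1cccs1)C(=O)COc1ccc(OC)cc1`: 120 nM

Compound 3 holds the lower of the two reported numbers; the gap to the next entry is a 3.5-fold lower number from compound 2 to compound 3 (0.55 log units; beyond the scatter). Compound 1 gave no number at all in this assay.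

Compound 4 `CCc1ccc(OCC(=O)N(CC)Cc2cccs2)cc1` differs from compound 3 in one place: ethyl in place of methoxy on an aromatic carbon.

Among the compounds with values here, the single measured step, a 3.5-fold lower number from compound 2 to compound 3 (0.55 log units; beyond the scatter), concerns methoxy entering for fluoro, a change on the same aromatic carbon; it shows that an exchange of this para group can shift the number modestly. Within the data shown here, no measured pair compares ethyl with methoxy, so nothing here tells whether the acceptor that leaves matters. Among the measured compounds shown here, because the only informative step is a 3.5-fold lower number from compound 2 to compound 3 (0.55 log units; beyond the scatter), and that step is modest, the expectation for this assay is a step within the scatter or a small rise, not a large one in either direction.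

For compound 4 the expected value in this assay is 160 nM, with a range of 60 nM to 450 nM. For compound 4 this corresponds to an expected step of a 1.3-fold higher number from compound 3 to compound 4 (0.12 log units; within the scatter).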

Compound 4, half-maximal effective concentration: 67 nM
Estimate against measurement, compound 4: 2.4-fold (0.38 log units) above; measured number inside the range.
By their numbers in this assay, from the lowest: compounds 4 and 3 (each within the scatter of the next); then compound 2.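

In this assay, ethyl in place of methoxy on the aromatic carbon gives a 1.8-fold lower number from compound 3 to compound 4 (0.25 log units; within the scatter) and so stays within the scatter, even though the hydrogen-bond acceptor counted for methoxy is lost. At this position a group with no hydrogen-bond acceptor can therefore match methoxy on this read-out. Ethyl in place of fluoro gives a 6.3-fold lower number from compound 2 to compound 4 (0.80 log units; beyond the scatter) and adds a second exchange beyond the scatter at this carbon. No measured evidence on the cause of these steps is available.

On these data alone, whether a longer chain such as propyl, or an amine, would hold the number near those of compound 3 and compound 4 remains open. Also open, as far as these compounds go, is whether an ester or amide could recover a number where compound 1, the carboxylic acid, gives "not active" (no number reported) in this assay on this carbon.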